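Compound 3 and the limit shared by its neighbours

The compounds below may be only part of what the source reports. "The series", "measured", "known", "first", "only" and "open" are said of these compounds alone.

Measured so far in an ADME assay on MRC5 cells (Homo sapiens) for cytotoxicity, read by fluorescence and resazurin assay, with a stated time of 3 days; a higher number here means that more compound is tolerated, a lower number that less compound is tolerated:
Compound 1 (`O=C(Nc1cc(-c2ccccn2)n[nH]1)N1CCC(c2cccc(F)c2)CC1`) gives > 64000 nM
Compound 2 (`O=C(Nc1cc(-c2ccccn2)n[nH]1)N1CCC(c2ccc(F)cc2)CC1`) gives > 64000 nM

Compound 1 gives only a limit of the assay, > 64000 nM in this assay and no number. Compound 2 likewise gives only a limit, > 64000 nM as its reading. Together they stand at the limit of > 64000 nM in this assay, at which 2 of the 2 values shown sit, and offer no graded scale.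

Compound 3 (`O=C(Nc1cc(-c2ccccn2)n[nH]1)N1CCC(c2ccc(Cl)cc2)CC1`) has not yet been measured. It differs from compound 1 by 4-chlorophenyl in place of 3-fluorophenyl on a saturated ring carbon, three ring bonds from the ring nitrogen. For the measured compounds named here, only one measured step bears on this change, a step that the two limits leave unreadable from compound 1 to compound 2, and it gives no readable size. Since compound 1 and compound 2 both sit at the limit of > 64000 nM in this assay, at which 2 of the 2 values shown sit, no step beyond the scatter is expected in this assay, and the reading may well stay at the limit. The expected change is a number no higher from compound 1 to compound 3 (the limit leaves the size open) and no more. Compound 3 is estimated at 64000 nM (expected range 32000 nM to 64000 nM).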

Compound 3, half-maximal cytotoxic concentration: > 62000 nM
Compound 3: only a limit was reported; the forecaster's own chance of this, stated with the estimate: 75%; the middle value does not contradict the limit.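

In this assay compound 3 gives > 62000 nM, which is a limit of the assay and not a number. For the compounds shown here, compound 1 and compound 2 also give only limits, so no step among compound 1, compound 2 and compound 3 can be read. The compounds shown leave open at what concentration any of them harms the cells, and whether exchanging fluoro for chloro changes that concentration.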